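The source may hold more compounds than are shown below. What is called first, only, known or untested is meant among the compounds shown, and "the series" means these compounds.

Compound 1 `COc1ccccc1-c1cn(C[C@H](O)[C@H]2OC(=O)C(OCc3ccccc3)=C2OCc2ccccc2)nn1`: in a functional assay on A549 cells (Homo sapiens) for antiproliferative activity, read by MTT assay, with a stated time of 72 h (on this read-out higher numbers stand for weaker inhibition and lower numbers for stronger inhibition), compound 1 reaches only the assay limit, > 100000 nM.
Compound 2 `CCCCCCCCCCc1cn(C[C@H](O)[C@H]2OC(=O)C(OCc3ccccc3)=C2OCc2ccccc2)nn1`: compound 2 gives 6750 nM.
Compound 3 `O=C1O[C@H]([C@@H](O)Cn2cc(CNS(=O)(=O)c3ccc(Cl)cc3)nn2)C(OCc2ccccc2)=C1OCc1ccccc1`: compound 3 gives 2870 nM.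

Compound 3 holds the lowest of the two actual numbers; compound 2 sits nearest, a 2.4-fold lower number from compound 2 to compound 3 (0.37 log units; beyond the scatter), while compound 1 contributes only a limit (the limit of > 100000 nM in this assay, at which 1 of the 3 values shown sits). Compound 4 `O=C1O[C@H]([C@@H](O)Cn2cc(-c3cc(F)cc(F)c3)nn2)C(OCc2ccccc2)=C1OCc1ccccc1` differs from compound 3 by 3,5-difluorophenyl in place of (((4-chlorophenyl)sulfonyl)amino)methyl on an aromatic carbon. The step that bears most on this change is an at least 34-fold lower number from compound 1 to compound 3 (1.54 log units; beyond the scatter), large and running in the opposite direction, since compound 1 likewise carries an aryl group directly on the five-membered aromatic ring with 3 nitrogen; a 2.4-fold lower number from compound 2 to compound 3 (0.37 log units; beyond the scatter) was modest. A large rise is therefore expected, a 10-fold higher number from compound 3 to compound 4 (1.02 log units; beyond the scatter). Compound 4 is estimated at 30000 nM, between 6000 nM and 150000 nM, with a real chance that only a limit is reported.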

Compound 4, half-maximal inhibitory concentration: 41200 nM
The estimate for compound 4 lay 1.4-fold (0.14 log units) below the measured number, and the stated range covers the measured number.
By their numbers in this assay, from the lowest: compound 3; then compound 2; then compound 4. At a limit, above all of these: compound 1.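

At this aromatic carbon of the five-membered aromatic ring with 3 nitrogen, 3,5-difluorophenyl loses much of what (((4-chlorophenyl)sulfonyl)amino)methyl reached in this assay, with a 14-fold higher number from compound 3 to compound 4 (1.16 log units; beyond the scatter). It also falls behind decyl, with a 6.1-fold higher number from compound 2 to compound 4 (0.79 log units; beyond the scatter), so both aryl groups set directly on this carbon, 2-methoxyphenyl and 3,5-difluorophenyl, now lie above the two compounds with chains. Compound 1 stands only at a limit, so an at least 2.4-fold lower number from compound 1 to compound 4 (0.38 log units; beyond the scatter) is a bound and not a measured gap, though it separates the two aryl groups: the limit of > 100000 nM in this assay, at which 1 of the 4 values shown sits.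

The compounds shown leave open whether a benzyl group, an amine or a carboxylic acid on this carbon would read nearer compound 3 or compound 4.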